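Varying the Aryl Ester of a Shared Oxime Core

A few compounds are considered here, and "the series" means these few. Any claim that something is new, unique, unknown or untested is made for them only; others in the source may bear on it.

Of the compounds shown here, three built on one shared core have been measured in a functional assay, read by spectrophotometry, with a stated time of 30 min; a higher number here means a weaker inhibitor, a lower number a stronger inhibitor. Compound 1 `COc1cc(C2CC(=NOC(=O)c3ccc(Br)cc3)CC(c3ccc(O)c(OC)c3)N2C)ccc1O` gives 108000 nM. Compound 2 `COc1cc(C2CC(=NO)CC(c3ccc(O)c(OC)c3)N2C)ccc1O`, which carries hydrogen in place of the (4-bromophenyl)carbonyl group on the oxygen, gives 158000 nM. Compound 3 `COc1cc(C2CC(=NOC(=O)c3ccc([N+](=O)[O-])cc3)CC(c3ccc(O)c(OC)c3)N2C)ccc1O` gives 79000 nM in this assay. Its standing relative to the others is told by two steps: a 1.4-fold lower number from compound 1 to compound 3 (0.14 log units; within the scatter) and a 2.0-fold lower number from compound 2 to compound 3 (0.30 log units; within the scatter), so compound 3 is not separated from either compound 1 or compound 2 beyond the usual scatter.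

Compound 4 `COc1cc(C2CC(=NOC(=O)c3ccccc3O)CC(c3ccc(O)c(OC)c3)N2C)ccc1O` differs from compound 3 in one place: 2-hydroxyphenyl in place of 4-nitrophenyl on a carbonyl carbon. Among the measured compounds shown here, the steps that bear on this change are those that alter the same aryl ester portion, a 1.4-fold lower number from compound 1 to compound 3 (0.14 log units; within the scatter) and a 2.0-fold lower number from compound 2 to compound 3 (0.30 log units; within the scatter), each within the scatter. Changing the aryl group, or removing the ester entirely, left the number essentially unchanged, so no step beyond the scatter is expected for a 1.3-fold higher number from compound 3 to compound 4 (0.10 log units; within the scatter) in this assay. Compound 4 is therefore estimated at 100000 nM, with a range from 45000 nM to 220000 nM.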

Compound 4, half-maximal inhibitory concentration: 15900 nM
Compound 4: the middle estimate sits 6.3-fold (0.80 log units) above what was measured; the measured number lies below the stated range.
By their numbers in this assay, from the lowest: compound 4; then compounds 3, 1 and 2 (each within the scatter of the next).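

In this assay, among the compounds shown here, the aryl group of the ester proves able to move the number: 2-hydroxyphenyl in place of 4-nitrophenyl gives a 5.0-fold lower number from compound 3 to compound 4 (0.70 log units; beyond the scatter), and in place of 4-bromophenyl it gives a 6.8-fold lower number from compound 1 to compound 4 (0.83 log units; beyond the scatter), whereas the earlier steps at this position all stayed within the scatter. Against the free oxime hydrogen, the (2-hydroxyphenyl)carbonyl group gives a 9.9-fold lower number from compound 2 to compound 4 (1.00 log units; beyond the scatter), so among the esters shown only this one separates from the hydrogen. The position is therefore sensitive to which aryl group it carries, not merely to the presence of an ester.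

A 2-methoxyphenyl, 2-aminophenyl or 4-hydroxyphenyl ester would show whether the step depends on the hydroxyl itself or on where it sits. No measurement here accounts for why this aryl group stands apart from the other two.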